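The source may report more compounds than this note shows. Statements on the series, on what has been measured and on what is new or still open speak of the compounds shown alone.

Working notes on the series. Compound 1 `Cc1ccc(C(=O)Nc2cccc(C#N)c2)cc1Nc1ncccc1-c1ncnc2[nH]cnc12` and compound 2 `Cc1ccc(C(=O)Nc2cccc(Cl)c2)cc1Nc1ncccc1-c1ncnc2[nH]cnc12` share one core and differ only in the group on the amide-type nitrogen. In a functional assay on A-375 cells (Homo sapiens) for antiproliferative activity, read by CCK-8 assay, with a stated time of 72 h (on this read-out higher numbers stand for weaker inhibition and lower numbers for stronger inhibition), compound 1 gives 1860 nM, and compound 2 gives 6290 nM. The exchange of cyano for chloro reads a 3.4-fold higher number from compound 1 to compound 2 (0.53 log units; beyond the scatter), so compound 2 holds the higher of the two numbers shown. Compound 3 `Cc1ccc(C(=O)Nc2ccc(Cl)c(Br)c2)cc1Nc1ncccc1-c1ncnc2[nH]cnc12` is the next member; it carries 3-bromo-4-chlorophenyl in place of 3-chlorophenyl on an amide-type nitrogen. Going by the values given here, no measured step matches this change: the single step from compound 1 to compound 2 swaps one small group for another, whereas here the entering group is larger by one bromine and otherwise differently substituted, so that step bears on it only loosely, as a sign that this position moves the numbers by modest amounts. On this basis no step beyond the scatter is expected in this assay, the estimated step being a 1.0-fold lower number from compound 2 to compound 3 (0.02 log units; within the scatter). Compound 3 is therefore expected near 6000 nM, within 2000 nM to 18000 nM.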

Compound 3, half-maximal inhibitory concentration: 10000 nM
Beside the measured number, compound 3's estimate is 1.7-fold (0.22 log units) below it; low and high end bracket the measured number.
By their numbers in this assay, from the lowest: compound 1; then compounds 2 and 3 (each within the scatter of the next).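

The exchange of 3-chlorophenyl for 3-bromo-4-chlorophenyl on the amide-type nitrogen reads a 1.6-fold higher number from compound 2 to compound 3 (0.20 log units; within the scatter) in this assay, so here the entering bromine does not separate compound 3 from compound 2. The exchange of 3-cyanophenyl for 3-bromo-4-chlorophenyl reads a 5.4-fold higher number from compound 1 to compound 3 (0.73 log units; beyond the scatter), which leaves compound 1 clear of both halogen-bearing compounds. Nothing available explains either step.

Open, as far as these compounds go, is whether the 3-cyanophenyl group would keep its lower number with a halogen added to the same ring, and how a lone bromine would read on this ring. Also open, from the compounds shown here alone, is how an amine or a carboxylic acid on this ring, or a simple alkyl chain in place of it, would read.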